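Adding a second nitro group to compound 2

This account rests on a few compounds, and the source may have more. Where it says the series, first, only, none or still open, it means among the compounds named here.

Compound 1 `O=C(NCCNS(=O)(=O)c1ccc(-c2ccccc2Oc2ccc([N+](=O)[O-])c([N+](=O)[O-])c2)s1)Nc1cc(Cl)cc(Cl)c1`: 2100 nM
Compound 2 `COc1ccc(NC(=O)NCCNS(=O)(=O)c2ccc(-c3ccccc3Oc3ccc([N+](=O)[O-])cc3)s2)cc1`: > 50000 nM, a limit

Both compounds were tested in a functional assay on RS4-11 cells (Homo sapiens) for inhibition, read by CCK-8 assay, with a stated time of 48 h; a lower number here means a stronger inhibitor, a higher number a weaker inhibitor. Compound 2 stands at the limit of > 50000 nM in this assay, at which 1 of the 2 values shown sits, so it has a limit and no number. Compound 3 `COc1ccc(NC(=O)NCCNS(=O)(=O)c2ccc(-c3ccccc3Oc3ccc([N+](=O)[O-])c([N+](=O)[O-])c3)s2)cc1` is compound 2 with nitro in place of hydrogen on an aromatic carbon, ortho to a nitro group and meta to a large group (nitro in place of hydrogen on an aromatic carbon). The change turns 4-nitrophenyl to 3,4-dinitrophenyl.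

Among the compounds with values here, no measured pair isolates this change. Compound 1 carries the 3,4-dinitrophenyl group and gives 2100 nM, but it also differs elsewhere from compound 3, so the expectation is loose. A gain beyond the scatter, toward a lower number in this assay, is still expected, with an estimated step of an at least 8.3-fold lower number from compound 2 to compound 3 (0.92 log units; beyond the scatter). The expected value for compound 3 is 6000 nM, within an estimated range from 1500 nM to 25000 nM.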

Compound 3, half-maximal inhibitory concentration: 1400 nM
Compound 3: the middle estimate sits 4.3-fold (0.63 log units) above what was measured; the whole stated range lies above it.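

In this assay, within the data shown here, nitro in place of hydrogen on an aromatic carbon, ortho to a nitro group and meta to a large group, gives an at least 35-fold lower number from compound 2 to compound 3 (1.55 log units; beyond the scatter), the first reading of this change with the rest of the structure held constant. The starting point of that step is a limit and not a number for compound 2: the limit of > 50000 nM in this assay, at which 1 of the 3 values shown sits. With the 3,4-dinitrophenyl group present, 4-methoxyphenyl in place of 3,5-dichlorophenyl on the amide-type nitrogen gives a 1.5-fold lower number from compound 1 to compound 3 (0.18 log units; within the scatter), which leaves the two compounds within the scatter of each other.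

On these data alone, it remains open whether a nitrile or an amine at this position would have a similar effect. As far as these compounds go, it also remains open whether 3,5-dichlorophenyl on the amide-type nitrogen would give a similar result alongside the 4-nitrophenyl group.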